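Replacing methoxycarbonyl with methylcarbamoyl

This account rests on a few compounds, and the source may have more. Where it says the series, first, only, none or still open, it means among the compounds named here.

Measured in a functional assay on NCI-H1993 cells (Homo sapiens) for inhibition, read by CCK-8 assay, with a stated time of 72 h; on this read-out lower numbers stand for stronger inhibition and higher numbers for weaker inhibition:
- compound 1 `CC(c1cc2cccnc2cc1F)n1cnc2ncc(-c3ccccc3)nc21`: 570 nM
- compound 2 `COC(=O)c1ccc(-c2cnc3ncn(C(C)c4cc5cccnc5cc4F)c3n2)cc1F`: 60.2 nM

Of these two, compound 2 has the lower number, making it the stronger inhibitor. Compound 3 `CNC(=O)c1ccc(-c2cnc3ncn(C(C)c4cc5cccnc5cc4F)c3n2)cc1F` differs from it in one place: methylamino in place of methoxy on a carbonyl carbon. Going by the values given here, one measured step bears on this, a 9.5-fold lower number from compound 1 to compound 2 (0.98 log units; beyond the scatter), where 3-fluoro-4-(methoxycarbonyl)phenyl replaced phenyl. That step shows this part of the molecule can shift the number, but it does not test the new swap. A modest further drop in this assay is expected, though no change remains possible. The expected step is a 2.4-fold lower number from compound 2 to compound 3 (0.38 log units; beyond the scatter). For compound 3 the estimated value is 25 nM, with a range from 5 nM to 110 nM.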

Compound 3, half-maximal inhibitory concentration: 32.7 nM
The estimate for compound 3 lay 1.3-fold (0.12 log units) below the measured number; low and high end bracket the measured number.
By their numbers in this assay, from the lowest: compounds 3 and 2 (each within the scatter of the next); then compound 1.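

Swapping methoxy for methylamino on the carbonyl carbon, read in this assay, leaves the two compounds within the scatter of each other (a 1.8-fold lower number from compound 2 to compound 3 (0.27 log units; within the scatter)). The methylcarbamoyl group therefore serves as well as methoxycarbonyl at this position, and the advantage over plain phenyl remains (a 17-fold lower number from compound 1 to compound 3 (1.24 log units; beyond the scatter)). Nothing given here explains either step.

Still open, going by these compounds, is how a carboxylic acid or a primary amide would compare on this carbonyl carbon. On these data alone, a longer chain on the amide nitrogen, such as ethylamino, is equally open.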